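Urea Terminus Change: From Propylamino to Dimethylamino

The compounds below may be only part of what the source reports. "The series", "measured", "known", "first", "only" and "open" are said of these compounds alone.

The series shares a single core, seen in compound 1 `CNC(=O)Nc1ccccc1-c1ccc(CN2C(=O)[C@H](NC(=O)CC(C)(C)N)CCc3ccccc32)cc1`, compound 2 `CNC(=O)NCc1ccccc1-c1ccc(CN2C(=O)[C@H](NC(=O)CC(C)(C)N)CCc3ccccc32)cc1` and compound 3 `CCCNC(=O)NCc1ccccc1-c1ccc(CN2C(=O)[C@H](NC(=O)C(C)(C)N)CCc3ccccc32)cc1`. In a functional assay (Pituitary gland cell) with Rattus norvegicus as the target (on this read-out lower numbers stand for an effect already at smaller amounts and higher numbers for an effect only at larger amounts of compound), compound 1 gives 50 nM, compound 2 gives 6 nM, and compound 3 gives 144 nM, which places compound 3 at the highest number of the three. Compound 4 `CN(C)C(=O)NCc1ccccc1-c1ccc(CN2C(=O)[C@H](NC(=O)C(C)(C)N)CCc3ccccc32)cc1` has not yet been measured in this assay.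

Within the data shown here, the one step within the measured set, an 8.3-fold lower number from compound 1 to compound 2 (0.92 log units; beyond the scatter), concerns the linkage of the urea to the ring and not the urea terminus. Compound 2 and compound 3 differ from each other in two places at once, so what they show for the urea terminus alone cannot be separated.

The change from compound 3 to compound 4 is dimethylamino in place of propylamino on a carbonyl carbon. Among the measured compounds shown here, no measured pair isolates a change of this kind, and the urea terminus is kept at a comparable size. The step from compound 3 to compound 4 in this assay is therefore expected to stay small, a 1.1-fold lower number from compound 3 to compound 4 (0.04 log units; within the scatter), without a clear direction. For compound 4 the estimated value is 130 nM, with a range from 40 nM to 450 nM.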

Compound 4, concentration for half-maximal effect: 60 nM
For compound 4 the middle estimate is 2.2-fold (0.34 log units) above the measured one; the range from low to high includes it.
By their numbers in this assay, from the lowest: compound 2; then compounds 1 and 4 (each within the scatter of the next); then compound 3.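

The urea terminus on the carbonyl carbon proves to be a position that can move the read-out: in this assay, dimethylamino in place of propylamino gives a 2.4-fold lower number from compound 3 to compound 4 (0.38 log units; beyond the scatter), a modest step but the first to isolate this terminus, which the two-place difference between compound 2 and compound 3 could not do. The step also shows that this terminus tolerates the change, since the value moves toward lower numbers when propylamino, with 4 heavy atoms and 1 hydrogen-bond donor, gives way to dimethylamino, with 3 heavy atoms and 0 hydrogen-bond donors. Nothing available explains why the number falls with this exchange.

The single step changes the heavy-atom count and the donor count together, so the compounds shown cannot say which of the two goes with the lower number, and an ethylamino or a diethylamino terminus on the same core would help to pull them apart. From the compounds shown here alone, whether dimethylamino gives a step of similar size alongside the amide side chain of compound 2 also remains open.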